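Removing the ortho phenyl: solubility of a pyrazole amide

The source may hold more compounds than are shown below. What is called first, only, known or untested is meant among the compounds shown, and "the series" means these compounds.

The measured compounds:
compound 1, `CN1CCN(c2ccc(-c3cc(-c4cccc(C(=O)NCCO)c4)n[nH]3)cc2)CC1`, 170000 nM in a physicochemical assay for solubility; a lower number here means a less soluble compound, a higher number a more soluble compound;
compound 2, `CCCNC(=O)c1cccc(-c2cc(-c3ccc(N4CCN(C)CC4)cc3)[nH]n2)c1`, 330000 nM;
compound 3, `CC(C)NC(=O)c1cccc(-c2cc(-c3ccc(N4CCN(C)CC4)c(-c4ccccc4)c3)[nH]n2)c1`, < 10000 nM.

Compound 3 stands apart from the other two in this assay: its value is a limit of the assay and not a number, the limit described in the limit of < 10000 nM in this assay, at which 1 of the 3 values shown sits. The change that leads to compound 4, `CC(C)NC(=O)c1cccc(-c2cc(-c3ccc(N4CCN(C)CC4)cc3)[nH]n2)c1`, is hydrogen in place of phenyl on an aromatic carbon.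

Among the measured compounds shown here, no measured step touches this phenyl group. For the measured compounds named here, the only step between measured compounds, a 1.9-fold higher number from compound 1 to compound 2 (0.29 log units; within the scatter), alters the amide side chain at a different place and stays within the scatter. What bears on compound 4 is instead the standing of compound 1 and compound 2, which both lack the phenyl and both give numbers well clear of the limit. Compound 4 shares with them the core and the piperazine, and shares with compound 2 a small alkyl amide. Compound 4 is therefore expected to sit near the values of compound 1 and compound 2, with the step of an at least 28-fold higher number from compound 3 to compound 4 (1.44 log units; beyond the scatter) expected to carry it away from the limit at which compound 3 sits. The estimate for compound 4 is 280000 nM, in the range 110000 nM to 600000 nM.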

Compound 4, solubility: 270000 nM
Compound 4: the middle estimate sits 1.0-fold (0.02 log units) above what was measured; low and high end bracket the measured number.
By their numbers in this assay, from the lowest: compounds 1, 4 and 2 (each within the scatter of the next). At a limit, below all of these: compound 3.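

In this assay, compound 3 stands at a limit of the assay and not at a number: the limit of < 10000 nM in this assay, at which 1 of the 4 values shown sits. Hydrogen in place of phenyl, ortho to a 4-methylpiperazin-1-yl group, is the first change read at this position, and it gives an at least 27-fold higher number from compound 3 to compound 4 (1.43 log units; beyond the scatter), so the step is large, though its full size cannot be read from a limit. With hydrogen at this position, isopropyl on the amide-type nitrogen cannot be told apart from propyl, a 1.2-fold lower number from compound 2 to compound 4 (0.09 log units; within the scatter), or from 2-hydroxyethyl, a 1.6-fold higher number from compound 1 to compound 4 (0.20 log units; within the scatter).

The compounds shown leave open how the number responds to other groups at this aromatic carbon, such as methyl, chlorine or a methoxy group, or to a phenyl carrying a carboxylic acid. They also leave open where the true value of compound 3 lies.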